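Methyl scan on two aryloxyacetic acid series

This account rests on a few compounds, and the source may have more. Where it says the series, first, only, none or still open, it means among the compounds named here.

Compound 1 `O=C(O)COc1ccc(NC(=O)C(=O)Nc2ccccc2)cc1F` shares a common acid-bearing core with compound 2 `Cc1ccc(NC(=O)C(=O)Nc2ccc(OCC(=O)O)c(F)c2)cc1` and compound 3 `O=C(O)COc1ccc(NC(=O)COc2ccccc2)cc1F`; compound 4 `Cc1ccccc1OCC(=O)Nc1ccc(OCC(=O)O)c(F)c1` is not yet measured. In a functional assay on CHO cells for agonist activity at Free fatty acid receptor 1 (Homo sapiens), read by FLIPR, tested at 100 nM (a lower number here means a weaker effect, a higher number a stronger effect of the compound at the concentration tested), compound 1 gives 9.78%, and compound 2 gives 11.4%. The change between them, (methyl in place of hydrogen on an aromatic carbon), is the step of a number 1.6 percentage points higher from compound 1 to compound 2 (within the scatter). Compound 3 gives 29.8% in this assay, the highest of the three numbers, beyond the scatter from both others; how its core differs from that of compound 1 is not broken down here. Compound 4 carries the change (methyl in place of hydrogen on an aromatic carbon). This is the same kind of change as from compound 1 to compound 2, but its place differs: there the methyl stands para to a large group, here ortho to a large group, and the rings also sit on different sides of the linker. For the measured compounds named here, with only the one earlier step as guide, the expected step from compound 3 to compound 4 in this assay is a number 2.2 percentage points higher from compound 3 to compound 4 (within the scatter), small because of a number 1.6 percentage points higher from compound 1 to compound 2 (within the scatter). Compound 4 is therefore expected to give about 32%, within 18% to 46%.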

Compound 4, a percentage reported as activity, at one concentration (the size of the read-out at that concentration, not a potency): 20.8%
Beside the measured number, compound 4's estimate is 11.2 percentage points above it; low and high end bracket the measured number.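

In this assay, methyl in place of hydrogen on an aromatic carbon gives a step of a number 9 percentage points lower from compound 3 to compound 4 (within the scatter) and so leaves no change that can be told from the scatter on this core. For the compounds shown here, this does not show that the methyl is without effect in general: only two pairs are at hand, the read-out comes from a single concentration and is not a potency, and the methyl stands at a different place in each pair. On these two cores, the change can be carried over without a difference between the steps that exceeds the scatter: the same change on two cores in this assay, a number 1.6 percentage points higher (within the scatter) from compound 1 to compound 2 and a number 9 percentage points lower (within the scatter) from compound 3 to compound 4, 10.6 percentage points apart, within the scatter of two such steps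

Still open, on these data alone, is whether a group other than methyl, such as a chlorine atom, a methoxy group or an amine, would move the read-out beyond the scatter when set ortho to a large group on the same ring. Also open, as far as these compounds go, is whether a longer chain between the ether oxygen and the carboxylic acid would change the picture on either core.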